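The source may hold more compounds than are shown below. What is called first, only, known or untested is meant among the compounds shown, and "the series" means these compounds.

Measured so far in a functional assay on CHO-K1 cells for antagonist activity at adenosine receptor A1 (Homo sapiens), read by a beta-galactosidase reporter and cAMP accumulation, with stated times of 15 min and 6 h; on this read-out higher numbers stand for weaker inhibition and lower numbers for stronger inhibition:
compound 1, `CC(C)c1ccc(-c2nc(N)c3cc(Cc4ccccc4)sc3n2)o1`, gives 283 nM;
compound 2, `Cn1cnc(-c2nc(N)c3cc(Cc4ccccc4)sc3n2)c1`, gives 2330 nM.

Within the data shown here, of these two numbers compound 2 holds the higher one; its only comparison is the step of an 8.2-fold higher number from compound 1 to compound 2 (0.92 log units; beyond the scatter). Compound 3, `Nc1nc(-c2cccnc2)nc2sc(Cc3ccccc3)cc12`, has not been measured yet. It differs from compound 2 in one place: pyridin-3-yl in place of 1-methyl-1H-imidazol-4-yl on an aromatic carbon. Among the measured compounds shown here, the only measured step at this same position is an 8.2-fold higher number from compound 1 to compound 2 (0.92 log units; beyond the scatter), which shows that the group here moves the number noticeably, yet no measured compound carries pyridin-3-yl, so the size is uncertain. Compound 3 is expected to give a lower number than compound 2, a step of about a 2.9-fold lower number from compound 2 to compound 3 (0.46 log units; beyond the scatter). The estimate for compound 3 is 800 nM, between 200 nM and 3200 nM.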

Compound 3, inhibition constant: 1420 nM
Beside the measured number, compound 3's estimate is 1.8-fold (0.25 log units) below it; measured number inside the range.
By their numbers in this assay, from the lowest: compound 1; then compounds 3 and 2 (each within the scatter of the next).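

Pyridin-3-yl in place of 1-methyl-1H-imidazol-4-yl gives a 1.6-fold lower number from compound 2 to compound 3 (0.22 log units; within the scatter) in this assay so this read-out does not separate these two groups, although one ring is five-membered and the other six-membered. Pyridin-3-yl in place of 5-isopropylfuran-2-yl gives a 5.0-fold higher number from compound 1 to compound 3 (0.70 log units; beyond the scatter) and so compound 1 now stands apart from two different groups, not just one. Nothing measured here explains this difference. Still open, as far as these compounds go, is whether the isopropyl group or the furan ring matters more, and how a plain phenyl ring or an amine at this position would read.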